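Acyl size on the open-chain amide of compound 3

A few compounds are considered here, and "the series" means these few. Any claim that something is new, unique, unknown or untested is made for them only; others in the source may bear on it.

Three members of the series have been measured in an assay on NIH3T3 cells for binding affinity to melatonin receptor type 1B (Homo sapiens) (on this read-out higher numbers stand for weaker inhibition and lower numbers for stronger inhibition), so far. Compound 1 `CCC(=O)NC[C@@H]1CC1c1cccc2oc(CCCCc3ccccc3)cc12` gives 2.8 nM, the lowest number of the set. Compound 2 `CC(C)C(=O)NC[C@@H]1CC1c1cccc2oc(CCCCc3ccccc3)cc12` gives 54 nM; the step of a 19-fold higher number from compound 1 to compound 2 (1.29 log units; beyond the scatter) is the only one in the set that enlarges the acyl side of the amide, and it weakens binding. Compound 3 `CC(=O)NCCCc1cccc2oc(CCCCc3ccccc3)cc12` gives 127 nM, the highest of the three numbers: the step of a 45-fold higher number from compound 1 to compound 3 (1.66 log units; beyond the scatter) replaces the ring-bearing linker of compound 1 with an open chain. Compound 3 and compound 2 differ in more than one place, so their values are only set side by side, with compound 3 the higher.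

Compound 4 `CC(C)C(=O)NCCCc1cccc2oc(CCCCc3ccccc3)cc12` is not yet measured. Its change from compound 3 is isopropyl in place of methyl on a carbonyl carbon. Among the compounds with values here, the step from compound 1 to compound 2 is the nearest precedent, since it also adds carbon on the acyl side of the amide, and it was large in the weakening direction. On that single precedent, a step of similar direction is expected for the open-chain amide, though the different linker leaves the size uncertain; the expected step is a 6.3-fold higher number from compound 3 to compound 4 (0.80 log units; beyond the scatter). Compound 4 is therefore estimated at 800 nM, within a range of 250 nM to 3000 nM.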

Compound 4, inhibition constant: 83 nM
Beside the measured number, compound 4's estimate is 9.6-fold (0.98 log units) above it, and the stated range ends above it.
By their numbers in this assay, from the lowest: compound 1; then compounds 2, 4 and 3 (each within the scatter of the next, the first and the last beyond it).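

Working notes: in this assay, isopropyl in place of methyl on a carbonyl carbon of the open-chain amide gives a 1.5-fold lower number from compound 3 to compound 4 (0.18 log units; within the scatter) and so does not separate the two acyl groups on this linker. The large rise seen with the ring-bearing linker, a 19-fold higher number from compound 1 to compound 2 (1.29 log units; beyond the scatter) as the earlier acyl step, therefore does not hold as a general rule for added carbon on the acyl side, although that step starts from propanoyl and not acetyl and is not the same change. With a 30-fold higher number from compound 1 to compound 4 (1.47 log units; beyond the scatter) as the step that changes the whole side chain, compound 1 stays apart from compound 4, and the acyl change on the open chain does nothing to close that gap.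

Nothing at hand accounts for the different acyl readings on the two linkers. Still open, going by these compounds, are whether propanoyl on the open chain, the direct match to compound 1, behaves like acetyl and isopropylcarbonyl there, and whether a longer chain such as butanoyl or a cyclopropylcarbonyl group holds the number at this position.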